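Two sulfonanilides, one swap, and an expected pKa shift

A few compounds are considered here, and "the series" means these few. Any claim that something is new, unique, unknown or untested is made for them only; others in the source may bear on it.

The study concerns a small set of aryl sulfonamides and follows how one exchange on an aromatic ring moves their acid dissociation. Compound 1 `Cc1ccc(S(=O)(=O)Nc2cccc([N+](=O)[O-])c2)cc1` and compound 2 `O=[N+]([O-])c1cccc(NS(=O)(=O)c2ccc(Cl)cc2)c1` share one core, while compound 3 `Cc1ccc(S(=O)(=O)Nc2ccc(Cl)cc2)cc1` and compound 4 `O=S(=O)(Nc1ccc(Cl)cc1)c1ccc(Cl)cc1` share another; how the two cores differ is not broken down here. In a physicochemical assay for acid dissociation, compound 1 gives 8.27, compound 2 gives 7.51, and compound 3 gives 9.02. Compound 3 thus stands highest of the three measured numbers, beyond the scatter of both others.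

The change from compound 1 to compound 2 is chloro in place of methyl on an aromatic carbon. It made a step of a number 0.76 log units lower from compound 1 to compound 2 (beyond the scatter). The change from compound 3 to compound 4 is chloro in place of methyl on an aromatic carbon; the leaving group, the entering group and the place are the same in both cases, so this is the same change made on a second core. It occurs twice among the compounds shown, and only one instance has been measured.

For the measured compounds named here, since the only measured example of this exchange, from compound 1 to compound 2, lowered the number in this assay by a modest and clear amount, a step of about a number 0.76 log units lower from compound 3 to compound 4 (beyond the scatter) is expected when compound 4 is compared with compound 3. Compound 4 is therefore estimated at 8.26 in this assay, with a range from 7.9 to 8.6 expected to hold most repeat measurements.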

Compound 4, acid dissociation constant: 8.3
Estimate against measurement, compound 4: 0.04 log units below; the range from low to high includes it.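

In this assay the exchange of methyl for chloro, on an aromatic carbon para to a large group, gave a number 0.72 log units lower from compound 3 to compound 4 (beyond the scatter) on the second core, while the same exchange had given a number 0.76 log units lower from compound 1 to compound 2 (beyond the scatter) on the first. The two steps run in the same direction and are close in size, so between these two cores the change carried over with little alteration, but two instances do not show that the step would hold on any further core or at another place on the ring. No measurement accompanying these results bears on what lies behind the shift.

The compounds shown carry only methyl or chloro at this place, which leaves open how a methoxy group, an amine or a carboxylic acid there would move the number in this assay on either core. Also open, from the compounds shown here alone, is whether the step would keep its size on a core carrying neither the nitro group of compound 1 nor the chloro group that compound 3 holds on its core.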